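Swapping the Purine Thioether for a Bare Thiadiazole

The source may report more compounds than this note shows. Statements on the series, on what has been measured and on what is new or still open speak of the compounds shown alone.

In a functional assay on MDA-MB-231 cells (Homo sapiens) for antiproliferative activity, read by MTT assay, with a stated time of 48 h (on this read-out higher numbers stand for weaker inhibition and lower numbers for stronger inhibition), compound 3 `O=C(Nc1cc(Sc2ncnc3nc[nH]c23)c(O)c2ccccc12)c1ccc(Cl)cc1` gives 23000 nM. Compound 2 `O=C(Nc1cc(Sc2ncn[nH]2)c(O)c2ccccc12)c1ccc2ccccc2c1` gives 45100 nM in this assay, a number that sits within the usual scatter of the value of compound 3, so the two cannot be ranked against each other. Compound 1 `Cc1nnc(Sc2cc(NC(=O)c3ccc(Cl)cc3)c3ccccc3c2O)s1` reaches only a limit of this assay, > 100000 nM, and no number is known for it. The change examined here leads to compound 4 `O=C(Nc1cc(Sc2nncs2)c(O)c2ccccc12)c1ccc(Cl)cc1`: a group of 5 heavy atoms (2 carbon, 2 nitrogen, 1 sulfur; one five-membered aromatic ring with 3 hetero atoms) in place of a group of 9 heavy atoms (5 carbon, 4 nitrogen; one five-membered aromatic ring with 2 hetero atoms, one six-membered aromatic ring with 2 hetero atoms), on a sulfur. Going by the values given here, one measured step bears on it, in reverse: an at least 4.3-fold lower number from compound 1 to compound 3 (0.63 log units; beyond the scatter), and the group that enters in compound 4 differs from the one in compound 1 only by a missing methyl group. That measured step is itself bounded by the limit of > 100000 nM in this assay, at which 1 of the 3 values shown sits, so its true size may be larger than stated. Running the same kind of change backwards, the number for compound 4 is expected to rise by about a 3.5-fold higher number from compound 3 to compound 4 (0.54 log units; beyond the scatter), a step beyond the scatter, quite possibly back to the limit. The estimate for compound 4 in this assay is 80000 nM, with a range from 30000 nM to 200000 nM.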

Compound 4, half-maximal inhibitory concentration: > 100000 nM
Compound 4 was reported as a limit; the forecaster's own chance of this, stated with the estimate: 40%; middle value at least 1.2-fold (0.09 log units) away from the limit.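

With the 1,3,4-thiadiazol-2-yl group in place of the larger group on the sulfur, and the rest of the molecule unchanged, this assay shows an at least 4.3-fold higher number from compound 3 to compound 4 (0.63 log units; beyond the scatter). The methyl group of compound 1 is therefore not needed for this loss, since the thiadiazole without it also ends at a limit of the assay rather than at a measurable number. How compound 1 and compound 4 compare with each other cannot be read, because both values are limits: the limit of > 100000 nM in this assay, at which 2 of the 4 values shown sit.

The compounds shown leave open whether a thiadiazole carrying an amine or a carboxylic acid where compound 1 has its methyl group would return a measurable number. Also open, going by these compounds, is whether a plain phenyl ring on the sulfur would stand with compound 3 or with compound 4.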